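The source may report more compounds than this note shows. Statements on the series, on what has been measured and on what is new or still open speak of the compounds shown alone.

For the measured compounds named here, the three compounds measured so far share a core in which an aryloxyacetamide carries two groups on its amide nitrogen. Compound 1 `Cc1ccc(OCC(=O)N(Cc2cccs2)c2cccnc2)cc1` is one of them; in an assay on HEK293 cells for agonist activity at transient receptor potential cation channel subfamily M member 8 (Homo sapiens), read by fluorescence and calcium flux, with a stated time of 15 min (a higher number here means that more compound is needed for the effect, a lower number that less compound is needed), compound 1 gives 198 nM. Compound 2 `CCN(Cc1cccs1)C(=O)COc1ccc(C(F)(F)F)cc1` gives 236 nM, a number within the usual scatter of that of compound 1, so the two cannot be ranked. Compound 3 `CCN(Cc1ccsc1)C(=O)COc1ccc(C)cc1` gives 88 nM, which lies beyond the scatter of the value of compound 1 and is the lowest number of the three, placing compound 1 second highest.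

Compound 4 `Cc1ccc(OCC(=O)N(CCO)Cc2cccs2)cc1` has not yet been measured. It differs from compound 1 in one place: 2-hydroxyethyl in place of pyridin-3-yl on an amide-type nitrogen. Going by the values given here, no pair among the measured compounds shows this exact change, so there is no step to lean on. Given that compound 1 sits at 198 nM and its neighbours span a narrow band, the step from compound 1 to compound 4 is expected to be small, at most a mild rise, a 1.5-fold higher number from compound 1 to compound 4 (0.18 log units; within the scatter). Compound 4 is therefore estimated at 300 nM, within 100 nM to 1000 nM.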

Compound 4, half-maximal effective concentration: 900 nM
Compound 4: middle estimate off by 3.0-fold (0.48 log units), on the low side; the measured number falls inside the stated range.
By their numbers in this assay, from the lowest: compound 3; then compounds 1 and 2 (each within the scatter of the next); then compound 4.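

In this assay, putting 2-hydroxyethyl in place of pyridin-3-yl on the amide-type nitrogen gives a 4.5-fold higher number from compound 1 to compound 4 (0.66 log units; beyond the scatter), so more compound is needed for the effect after this change. For the compounds shown here, this is the first single-place step, and it shows that the group at this position can move the number beyond the usual scatter. Nothing at hand explains why the number moves with this swap.

The swap removes a six-membered aromatic ring and adds a chain with a hydrogen-bond donor, and this single step cannot show which of these goes with the higher number. A phenyl ring or a 2-methoxyethyl chain at this position on the core of compound 1 would be needed to tell the two apart.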